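A few compounds are considered here, and "the series" means these few. Any claim that something is new, unique, unknown or untested is made for them only; others in the source may bear on it.

Three close relatives of one shared core have been tested so far. Compound 1 `N#CC1=C(N)Oc2c(c3nc4ccccc4nc3c3ccccc23)C12C(=O)N(Cc1cnnn1-c1ccc(Cl)cc1)c1ccccc12` carries a chlorophenyl group on the five-membered ring; compound 2 `CC(=O)Nc1ccc(-n2nncc2CN2C(=O)C3(C(C#N)=C(N)Oc4c3c3nc5ccccc5nc3c3ccccc43)c3ccccc32)cc1` carries an acetamidophenyl group there instead; compound 3 `CC(=O)Nc1ccc(-n2nncc2CN2C(=O)C3(C(C#N)=C(N)Oc4c(N)cc5nc6ccccc6nc5c43)c3ccccc32)cc1` keeps that acetamidophenyl group and adds an amino group to the core. In a functional assay on MCF7 cells (Homo sapiens) for antiproliferative activity, read by MTT assay, with a stated time of 48 h (on this read-out higher numbers stand for weaker inhibition and lower numbers for stronger inhibition), compound 1 gives > 50000 nM, which is a limit of the assay and not a number. In this assay compound 2 gives > 50000 nM, again a limit rather than a number. Among the compounds with values here, the only single change between measured compounds, acetamido in place of chloro on an aromatic carbon, a step that the two limits leave unreadable from compound 1 to compound 2, cannot be sized because the limit of > 50000 nM in this assay, at which 3 of the 3 values shown sit, holds both of its ends.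

Compound 3 stands with the other two. In this assay compound 3 gives > 50000 nM, once more a limit of the assay and not a number.

The next compound, compound 4 `N#CC1=C(N)Oc2c(N)cc3nc4ccccc4nc3c2C12C(=O)N(Cc1cnnn1-c1ccc([N+](=O)[O-])cc1[N+](=O)[O-])c1ccccc12`, differs from compound 3 in one place: 2,4-dinitrophenyl in place of 4-acetamidophenyl on an aromatic nitrogen. Within the data shown here, no measured step gives a readable size for a change of the group on that aromatic nitrogen, so no direction can be drawn from the data. Compound 4 is therefore expected to remain near the limit, with a step of a number no higher from compound 3 to compound 4 (the limit leaves the size open) and an estimated value of 50000 nM, ranging from 15000 nM to 50000 nM.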

Compound 4, half-maximal inhibitory concentration: 20900 nM
The estimate for compound 4 lay 2.4-fold (0.38 log units) above the measured number, within the range that was stated.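

Swapping 4-acetamidophenyl for 2,4-dinitrophenyl on the aromatic nitrogen gives an at least 2.3-fold lower number from compound 3 to compound 4 (0.37 log units; beyond the scatter) in this assay, the first step among these compounds with a readable size. It shows that the group at this place can shift the read-out, which the earlier change on the same phenyl ring, chloro to acetamido, could not show. The size is only a lower bound, as one end of the step still sits at the limit that also leaves the earlier step unreadable: the limit of > 50000 nM in this assay, at which 3 of the 4 values shown sit.

From the compounds shown here alone, whether both nitro groups are needed remains open, as does whether a single nitro group, a carboxylic acid or a methoxy group on that phenyl ring would lower the number in the same way. Also open, going by these compounds, is what part the amino group on the core plays. The 2,4-dinitrophenyl group appears here only together with it, and one step cannot separate the loss of the amide from the arrival of the nitro groups.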